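Removing the methylthiosemicarbazide group from compound 1

This account rests on a few compounds, and the source may have more. Where it says the series, first, only, none or still open, it means among the compounds named here.

This account follows a single change to compound 1 `CNC(=S)NNC(=O)Cn1c(=O)oc2ccc(C)cc21`. In a functional assay on the whole organism for inhibition, with Mus musculus as the target, read by paw edema, with a stated time of 180 min, at a dose of 100 mg/kg by the oral route (on this read-out lower numbers stand for a weaker effect and higher numbers for a stronger effect at the one dose given), compound 1 gives 33.8%, and compound 2 `CCNc1nnc(Cn2c(=O)oc3ccc(C)cc32)s1` gives 33.8%, so the two stand level at the digits shown and share the top of the three numbers available. Compound 3 `CCCn1c(Cn2c(=O)oc3ccc(C)cc32)n[nH]c1=S` gives 24.1%, a figure that lies within the scatter of the other two, so no ordering among the three can be claimed.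

Compound 4 `Cc1ccc2oc(=O)n(CC(=O)NN)c2c1` differs from compound 1 in one place: a hydrogen atom in place of a group of 4 heavy atoms (2 carbon, 1 nitrogen, 1 sulfur; no ring), on an amine nitrogen. Within the data shown here, no measured pair in this set isolates such a change, so there is no measured step to lean on. Given that every compound measured here, including compound 1 with 33.8%, sits within the scatter of the others, compound 4 is expected to show no step beyond the scatter in this assay, the step from compound 1 to compound 4 being estimated as a number 3.8 percentage points lower from compound 1 to compound 4 (within the scatter). Compound 4 is therefore expected to give about 30%, with a range from 15% to 45%.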

Compound 4, a percentage reported as inhibition, in the whole organism at one dose (the size of the read-out at that dose, not a potency): 70.5%
Estimate against measurement, compound 4: 40.5 percentage points below; the measured number lies above the stated range.
By their numbers in this assay, from the lowest: compounds 3, 1 and 2 (each within the scatter of the next); then compound 4.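

The earlier compounds shown here offered no measured step at this place, and this pair supplies the first: on the amine nitrogen whose other neighbour is the amide-type nitrogen, a hydrogen atom in place of the group of 4 heavy atoms gives a number 36.7 percentage points higher from compound 1 to compound 4 (beyond the scatter) in this assay, a step beyond the scatter. The group carried by compound 1 at this place is therefore not needed for the effect at this dose, and its removal goes with a much larger read-out. Nothing among the available data accounts for this step.

A single pair cannot show whether a small group on the same nitrogen, such as methyl or acetyl, would retain the read-out of compound 4 or return it towards that of compound 1. Going by these compounds, because each number comes from one dose, how the compounds compare in potency also remains open.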